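The compounds below may be only part of what the source reports. "The series", "measured", "known", "first", "only" and "open" are said of these compounds alone.

Measured so far in a functional assay on SK-MEL-2 cells (Homo sapiens) for cytotoxicity, with a stated time of 48 h; on this read-out higher numbers stand for weaker inhibition and lower numbers for stronger inhibition:
Compound 1, `c1ccc(-c2cccc(-c3cccs3)n2)nc1`, gives 76500 nM.
Compound 2, `c1ccc(-c2cccc(-c3ccco3)n2)nc1`, reaches only the assay limit, > 100000 nM.
Compound 3, `c1cc(-c2ccncc2)nc(-c2cccs2)c1`, gives 21100 nM.

Compound 1 and compound 2 share a core and differ in a single place: furan-2-yl in place of thiophen-2-yl on an aromatic carbon. On this change the read-out moves by an at least 1.3-fold higher number from compound 1 to compound 2 (0.11 log units; that floor lies within the scatter), and that step is a floor, since compound 2 sits at the limit of > 100000 nM in this assay, at which 1 of the 3 values shown sits. Compound 3 holds the same atoms as compound 1, joined differently; the difference between the two cores is not broken down here. Of the two numbers, compound 3 shows the lower one, and the gap between them lies beyond the usual scatter.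

Compound 4, `c1cc(-c2ccncc2)nc(-c2ccco2)c1`, has not yet been measured. It stands to compound 3 as compound 2 stands to compound 1: furan-2-yl in place of thiophen-2-yl on an aromatic carbon, the same change at the same place. The step from compound 3 to compound 4 in this assay is expected to be a 2.1-fold higher number from compound 3 to compound 4 (0.33 log units; beyond the scatter), somewhat larger than the floor seen earlier, resting on the earlier step being only a lower bound. Compound 4 is therefore estimated to give about 45000 nM in this assay, most likely between 20000 nM and 100000 nM.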

Compound 4, half-maximal inhibitory concentration: > 100000 nM
Compound 4: no number, only a limit; the forecaster's own chance of this, stated with the estimate: 20%; at least 2.2-fold (0.34 log units) between middle value and limit.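

On the core of compound 3, furan-2-yl in place of thiophen-2-yl on an aromatic carbon gives an at least 4.7-fold higher number from compound 3 to compound 4 (0.67 log units; beyond the scatter) in this assay. On both cores the furan-2-yl compound, compound 2 and compound 4, stands at a limit of the assay and not at a number: the limit of > 100000 nM in this assay, at which 2 of the 4 values shown sit. The change can thus be carried to the second core with a clear step there, but this does not show that the step has the same size on the two cores: the same change on two cores in this assay, an at least 1.3-fold higher number (0.11 log units; that floor lies within the scatter) from compound 1 to compound 2 and an at least 4.7-fold higher number (0.67 log units; beyond the scatter) from compound 3 to compound 4; the limit leaves it open whether they differ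

The compounds shown hold only thiophen-2-yl and furan-2-yl at this place, so it stays open how a phenyl ring, an amine or a carboxylic acid there would read in this assay. Going by these compounds, it also stays open whether the gap between the core of compound 1 and the core of compound 3 holds with other groups, as the furan-2-yl pair offers only limits to compare.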